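A few compounds are considered here, and "the series" means these few. Any claim that something is new, unique, unknown or untested is made for them only; others in the source may bear on it.

Measured so far:
- compound 1, `CCn1c(CN2CCN(C(=O)C3CC3)CC2)nc2ccccc21`: 20.8%
- compound 2, `Cc1cccc(Cn2c(CN3CCN(C(=O)CC(C)C)CC3)nc3ccccc32)c1`: 71.4%

The series is followed in an assay on isolated protein for inhibition of aldehyde dehydrogenase 1A1 (Homo sapiens), read by spectrophotometry, tested at 10 uM; on this read-out higher numbers stand for more inhibition at the one concentration tested (going by the name of the read-out) and lower numbers for less inhibition. Two compounds carry numbers. Compound 1 gives 20.8%, the lower of the two. Compound 2 gives 71.4%, a reading that stands beyond the usual scatter above compound 1. For the measured compounds named here, no pair of measured compounds differs in one place only, so no step between them can be computed; compound 2 differs from compound 1 both on the aromatic nitrogen and at the amide, and its higher number cannot be assigned to either change.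

Compound 3, `CCCCn1c(CN2CCN(C(=O)C3CC3)CC2)nc2ccccc21`, is not yet measured. It differs from compound 1 as follows: ethyl in place of hydrogen on a saturated chain carbon, two bonds along the chain from an aromatic nitrogen.

What to expect of this change rests only on the shown numbers. Going by the values given here, the only other compound, compound 2, carries a larger group on the aromatic nitrogen and reads higher, but that compound also differs at the amide, so the comparison is not clean. A modest rise is expected, of a size near the scatter, not a large one; the step from compound 1 to compound 3 is estimated at a number 12.2 percentage points higher from compound 1 to compound 3 (beyond the scatter). Compound 3 is therefore expected to give about 33%, within a range of 14% to 58%.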

Compound 3, a percentage reported as inhibition, at one concentration (the size of the read-out at that concentration, not a potency): 18.2%
Beside the measured number, compound 3's estimate is 14.8 percentage points above it; measured number inside the range.
By their numbers in this assay, from the lowest: compounds 3 and 1 (each within the scatter of the next); then compound 2.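

In this assay, for the compounds shown here, the first step that can be read at one place alone is ethyl in place of hydrogen on a saturated chain carbon, two bonds along the chain from an aromatic nitrogen, and it reads a number 2.6 percentage points lower from compound 1 to compound 3 (within the scatter). With the rest of the structure held fixed, this change from ethyl to butyl on the aromatic nitrogen therefore gives no reading distinguishable from that of the shorter chain, so added chain length of this size does not by itself account for a high number in this series. No measurement at hand bears on why the two compounds read alike.

Still open, from the compounds shown here alone, is whether the high reading of compound 2 (71.4%) belongs to the larger group on the aromatic nitrogen, to its amide, or to the two together, and a compound changed at only one of these places would be needed to separate them. Also open, going by these compounds, is how this position responds to groups other than plain chains, such as an unsubstituted benzyl group, a longer chain, or a butyl chain ending in an amine or a carboxylic acid.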